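Chloro to Amino on a Fused Core: Cytotoxicity Outlook

A few compounds are considered here, and "the series" means these few. Any claim that something is new, unique, unknown or untested is made for them only; others in the source may bear on it.

Compound 1, `ClCc1ccc(Cn2cnc3c(Cl)ncnc32)cc1`, in this study gives > 100000 nM.
Compound 2, `ClCc1cccc(Cn2cnc3c(Cl)nc(Cl)nc32)c1`, gives > 100000 nM.
Compound 3, `ClCc1ccccc1Cn1cnc2ncnc(Cl)c21`, gives > 100000 nM.

Each of these readings is a limit of a functional assay on COLO 205 cells (Homo sapiens) for cytotoxicity, read by sulforhodamine B assay, with a stated time of 48 h (a lower number here means that less compound is tolerated, a higher number that more compound is tolerated), rather than a number. Compound 2 stands with the other two at that limit, as the limit of > 100000 nM in this assay, at which 3 of the 3 values shown sit, records, and nothing on the values shown sets it apart from compound 1 or compound 3. Compound 4, `Nc1nc(Cl)c2ncn(Cc3cccc(CCl)c3)c2n1`, differs from compound 2 by amino in place of chloro on an aromatic carbon. Among the compounds with values here, no step between measured compounds is available, and all measured values are limits. In this assay the step is expected to be none beyond the scatter, most likely ending again at a limit: a number no higher from compound 2 to compound 4 (the limit leaves the size open). Compound 4 is expected to give 100000 nM, within 30000 nM to 300000 nM.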

Compound 4, concentration lethal to 50% of the cells: 97700 nM
Beside the measured number, compound 4's estimate is 1.0-fold (0.01 log units) above it, and the stated range covers the measured number.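

In this assay, within the data shown here, compound 4 gives 97700 nM, the first reading in this set that is a number and not a limit. Compound 2 remains a limit, so the change can be read only as a floor: the limit of > 100000 nM in this assay, at which 3 of the 4 values shown sit. Amino in place of chloro on this aromatic carbon, between two ring nitrogen atoms, gives an at least 1.0-fold lower number from compound 2 to compound 4 (0.01 log units; that floor lies within the scatter), and the true size of the step stays unknown.

Going by these compounds, whether a methylamino or a methoxy group on this carbon would read differently stays open. So does how an amine would read in place of the remaining chloro on the core.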